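The source may hold more compounds than are shown below. What is called first, only, known or untested is meant among the compounds shown, and "the series" means these compounds.

Compound 2 `Cc1ccc(-c2cn(Cc3ccccc3)nn2)cc1` and compound 1 `O=[N+]([O-])c1ccc(-c2cn(Cc3ccccc3)nn2)cc1` share one core and differ only in the group on the aromatic carbon. In a functional assay on B16 cells (Mus musculus) for cytotoxicity, read by MTT assay, with a stated time of 48 h (a lower number here means a stronger inhibitor, a higher number a weaker inhibitor), compound 1 gives 5120 nM. For compound 2 the same assay reports no number but a limit, > 100000 nM, which places compound 2 at the weak end of the two values shown (the limit of > 100000 nM in this assay, at which 1 of the 2 values shown sits). For the measured compounds named here, the only measured step is an at least 19-fold higher number from compound 1 to compound 2 (1.29 log units; beyond the scatter). Compound 3 `FC(F)(F)c1ccc(-c2cn(Cc3ccccc3)nn2)cc1` differs from compound 2 by trifluoromethyl in place of methyl on an aromatic carbon. Going by the values given here, that measured step bears on it only indirectly: it shows that a group other than methyl at this carbon can sit well away from the limit, while no measured pair contains trifluoromethyl. The step expected for compound 3 is an at least 4.0-fold lower number from compound 2 to compound 3 (0.60 log units; beyond the scatter), toward a lower number, its size uncertain. Compound 3 is therefore estimated at about 25000 nM in this assay, within 5000 nM to 100000 nM.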

Compound 3, half-maximal inhibitory concentration: > 100000 nM
Compound 3: only a limit was reported; the forecaster's own chance of this, stated with the estimate: 35%; at least 4.0-fold (0.60 log units) between middle value and limit.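

In this assay compound 3 gives a limit and not a number, and the limit now holds most of the series: the limit of > 100000 nM in this assay, at which 2 of the 3 values shown sit.

Trifluoromethyl in place of nitro on this aromatic carbon gives an at least 19-fold higher number from compound 1 to compound 3 (1.29 log units; beyond the scatter), so among the three groups shown, only nitro gives a measured value in this assay. The step from compound 2 to compound 3 cannot be read, and methyl and trifluoromethyl cannot be ordered at this position.

On these data alone, it remains open whether the measurable activity is particular to nitro or also appears with other groups on this carbon, such as a nitrile, an amine or a carboxylic acid. Also open, as far as these compounds go, is how a change elsewhere on the shared core would shift compound 1 from its 5120 nM.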